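Lengthening a nitroimidazole-bearing chain on two quinazoline anilines

The source may report more compounds than this note shows. Statements on the series, on what has been measured and on what is new or still open speak of the compounds shown alone.

All three measured compounds share a core carrying an anilino group and a flexible chain that ends in a 2-nitro-1H-imidazol-1-yl group, and all were tested in a functional assay on HT-29 cells (Homo sapiens) for inhibition, read by sulforhodamine B assay, with a stated time of 72 h; a lower number here means a stronger inhibitor, a higher number a weaker inhibitor. Compound 1 `COc1cc2c(Nc3ccc(OCc4cccc(F)c4)c(Cl)c3)ncnc2cc1OCCCCCn1ccnc1[N+](=O)[O-]` gives 14100 nM in this assay. Compound 2 `COc1cc2c(Nc3ccc(OCc4cccc(F)c4)c(Cl)c3)ncnc2cc1OCCCCCCn1ccnc1[N+](=O)[O-]` returns only a limit of the assay in this assay, > 50000 nM. The change between them is (2-nitro-1H-imidazol-1-yl)methyl in place of 2-nitro-1H-imidazol-1-yl on a saturated chain carbon, five bonds along the chain from an oxygen on an aromatic ring, and it produced an at least 3.5-fold higher number from compound 1 to compound 2 (0.54 log units; beyond the scatter); the size of that step rests on (the limit of > 50000 nM in this assay, at which 1 of the 3 values shown sits), so only its lower bound is known.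

Compound 3 `COc1cc2c(Nc3cccc(Br)c3)ncnc2cc1OCCCn1ccnc1[N+](=O)[O-]` carries a different anilino group and a shorter chain, and the difference between the two cores is not broken down here. In this assay compound 3 gives 10900 nM, which is within the usual scatter of the value for compound 1.

Compound 4 `COc1cc2c(Nc3cccc(Br)c3)ncnc2cc1OCCCCn1ccnc1[N+](=O)[O-]` has not yet been measured in this assay. Its difference from compound 3 is (2-nitro-1H-imidazol-1-yl)methyl in place of 2-nitro-1H-imidazol-1-yl on a saturated chain carbon, three bonds along the chain from an oxygen on an aromatic ring. Going by the values given here, this is the same kind of change as the one from compound 1 to compound 2, though the place differs: there the group sat five bonds along the chain from an oxygen on an aromatic ring, here three bonds. Going by the earlier step, compound 4 is expected to give a weaker number, with an estimated step of a 2.0-fold higher number from compound 3 to compound 4 (0.30 log units; within the scatter). The estimate for compound 4 is 22000 nM, with a range from 8000 nM to 50000 nM.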

Compound 4, half-maximal inhibitory concentration: 4020 nM
Compound 4: middle estimate off by 5.5-fold (0.74 log units), on the high side, outside the stated range (below it).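

In this assay, putting (2-nitro-1H-imidazol-1-yl)methyl in place of 2-nitro-1H-imidazol-1-yl on a saturated chain carbon, three bonds along the chain from an oxygen on an aromatic ring, gives a 2.7-fold lower number from compound 3 to compound 4 (0.43 log units; beyond the scatter). The same kind of change on the other core went the opposite way, so in this series it did not carry over from one core to the other, in direction or in size: the same change on two cores in this assay, an at least 3.5-fold higher number (0.54 log units; beyond the scatter) from compound 1 to compound 2 and a 2.7-fold lower number (0.43 log units; beyond the scatter) from compound 3 to compound 4, at least 9.6-fold (0.98 log units) apart, beyond the scatter of two such steps. This does not show what lies behind the reversal, as the two pairs differ both in the anilino group and in the place of the change along the chain, and the earlier step is known only as a lower bound, with compound 2 standing at a limit of the assay: the limit of > 50000 nM in this assay, at which 1 of the 4 values shown sits.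

Still open, going by these compounds, is how a longer chain on the core of compound 3, or a shorter chain on the core of compound 1, would read in this assay, which could help separate the part played by the core from the part played by the chain. Also open, on these data alone, is whether an amine or a carboxylic acid in place of the 2-nitro-1H-imidazol-1-yl group at the chain end would give values like these.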